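Fluorine shifted around the biaryl in a pyrazole acid series

The source may hold more compounds than are shown below. What is called first, only, known or untested is meant among the compounds shown, and "the series" means these compounds.

Three compounds of the shared core carrying an aromatic arm have been measured in an assay on isolated protein for inhibition of 2-Hydroxyacid oxidase 2 (Rattus norvegicus); on this read-out higher numbers stand for weaker inhibition and lower numbers for stronger inhibition. Compound 1 `Cc1n[nH]c(C(=O)O)c1Cc1ccc2ccccc2n1` gives 1700 nM in this assay. Compound 2 `Cc1n[nH]c(C(=O)O)c1Cc1cccc(-c2cccc(F)c2)c1` gives 500 nM, and compound 3 `Cc1n[nH]c(C(=O)O)c1Cc1ccc(Oc2ccccc2)cc1` gives 500 nM. Compound 2 and compound 3 are level at the digits shown, and together they hold the lowest numbers of the three; compound 1 sits clearly higher, beyond the usual scatter of this assay, so the two biaryl-type arms are read as the stronger inhibitors among these.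

The next step goes from compound 2 to compound 4 `Cc1n[nH]c(C(=O)O)c1Cc1cccc(-c2ccccc2F)c1`, not yet measured. The change is 2-fluorophenyl in place of 3-fluorophenyl on an aromatic carbon; in words, 2-fluorophenyl in place of 3-fluorophenyl on an aromatic carbon. Among the measured compounds shown here, no measured pair covers this move, so no step size is known for it. The expectation is that compound 4 stays close to compound 2, with at most a small shift toward a higher number, so that the step of a 1.4-fold higher number from compound 2 to compound 4 (0.15 log units; within the scatter) is expected to lie within the scatter or only just beyond it.

Compound 4 is therefore estimated at 700 nM in this assay, with a range from 250 nM to 2000 nM.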

Compound 4, half-maximal inhibitory concentration: 900 nM
Compound 4: middle estimate off by 1.3-fold (0.11 log units), on the low side; measured number inside the range.
By their numbers in this assay, from the lowest: compounds 2, 3, 4 and 1 (each within the scatter of the next, the first and the last beyond it).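

Putting 2-fluorophenyl in place of 3-fluorophenyl gives a 1.8-fold higher number from compound 2 to compound 4 (0.26 log units; within the scatter) in this assay, so this read-out does not separate the two isomeric arms. Among the compounds shown here, this is the first pair that differs in one place, and it shows that this aromatic carbon, meta to a large group, carries either fluorophenyl group with no difference that can be told from repeat-measurement noise, although the two groups have the same atoms and the same counts. No supporting measurement bears on what the fluorine does in either arrangement, and the step alone cannot say.

Still open, from the compounds shown here alone, is whether the fluorine contributes to inhibition at all, since a plain phenyl group at this place would set the baseline for both fluorophenyl arms. Also open, going by these compounds, is how far this tolerance extends, which a chlorine or a methoxy group in place of the fluorine on the same arm would begin to test.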